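Removing the methyl from the methoxy(methyl)amide of compound 3

This account rests on a few compounds, and the source may have more. Where it says the series, first, only, none or still open, it means among the compounds named here.

Among the compounds measured in an assay on isolated protein for inhibition of Apoptosis regulator Bcl-2 (Homo sapiens), read by fluorescence polarization, with stated times of 5 min and 10 min (on this read-out lower numbers stand for stronger inhibition and higher numbers for weaker inhibition), compound 3 `CON(C)C(=O)[C@H]1CC=C(CCC=C(C)C)C[C@@H]1c1ccccc1` stands at the lowest number, giving 300 nM. Compound 1 `COC(=O)CCNC(=O)[C@H]1CC=C(CCC=C(C)C)C[C@@H]1c1ccccc1` gives 3100 nM in this assay, so that the step of a 10-fold lower number from compound 1 to compound 3 (1.01 log units; beyond the scatter) is large. Compound 2 `CC(C)=CCCC1=CC[C@H](C(N)=O)[C@@H](c2ccccc2)C1` reaches only a limit of the assay, > 23000 nM, which is the limit of > 23000 nM in this assay, at which 1 of the 3 values shown sits.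

Compound 4 `CONC(=O)[C@H]1CC=C(CCC=C(C)C)C[C@@H]1c1ccccc1` is the not yet measured partner of compound 3; the difference between them is hydrogen in place of methyl on an amide-type nitrogen. Going by the values given here, two measured steps bear on it. The step of an at least 7.4-fold higher number from compound 1 to compound 2 (0.87 log units; beyond the scatter) shows that taking a substituent off the amide-type nitrogen, leaving a hydrogen, raised the number markedly. The step of an at least 76-fold lower number from compound 2 to compound 3 (1.88 log units; beyond the scatter) shows the reverse direction, where the fully substituted methoxy(methyl)amino gave the lowest number of the set. The change to compound 4 removes only the methyl and keeps the methoxy on the nitrogen, so it sits between those two extremes, and a modest rise in the number is expected rather than a large one.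

Compound 4 is therefore estimated to give 900 nM in this assay, within a range of 300 nM to 3000 nM, which would mean an expected step of a 3.0-fold higher number from compound 3 to compound 4 (0.48 log units; beyond the scatter).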

Compound 4, inhibition constant: 2400 nM
Beside the measured number, compound 4's estimate is 2.7-fold (0.43 log units) below it; the range from low to high includes it.
By their numbers in this assay, from the lowest: compound 3; then compounds 4 and 1 (each within the scatter of the next). At a limit, above all of these: compound 2.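

In this assay, the methyl alone on the amide-type nitrogen carries weight, even with the methoxy kept in place: an 8.0-fold higher number from compound 3 to compound 4 (0.90 log units; beyond the scatter). The methoxy without that methyl still counts against the amide hydrogen, an at least 9.5-fold lower number from compound 2 to compound 4 (0.98 log units; beyond the scatter), though this step rests on a limit of the assay: the limit of > 23000 nM in this assay, at which 1 of the 4 values shown sits. Replacing 2-(methoxycarbonyl)ethyl with methoxy on that nitrogen, however, gives a 1.3-fold lower number from compound 1 to compound 4 (0.11 log units; within the scatter), so these two substituents are not told apart here, and only the methoxy and methyl together, as in compound 3, separate clearly from the rest.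

The compounds shown leave open whether the methyl needs the methoxy at all, as a dimethylamide or a simple methylamide would test, and whether an ethyl in place of the methyl, or an ethoxy or hydroxy in place of the methoxy, would hold the number of compound 3. They also give no reason why this single methyl matters, and they show the change only on this one core and in this one assay.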